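From an Iodine Atom to a Benzofuran Ring

A few compounds are considered here, and "the series" means these few. Any claim that something is new, unique, unknown or untested is made for them only; others in the source may bear on it.

Three compounds built on the shared core have been compared in a functional assay on HCT-116 cells (Homo sapiens), read by MTT assay, with a stated time of 72 h; a lower number here means a stronger inhibitor, a higher number a weaker inhibitor. Compound 1 `Cc1ncnc2c1c(-c1cc3ccccc3o1)cn2[C@@H]1O[C@H](CO)[C@@H](O)[C@H]1O` carries a methyl group and a 1-benzofuran-2-yl group. In this assay compound 1 gives only a limit, > 20000 nM. Compound 2 `COc1ncnc2c1c(-c1cccs1)cn2[C@@H]1O[C@H](CO)[C@@H](O)[C@H]1O` carries a methoxy group and a thiophen-2-yl group, and in this assay compound 2 gives 440 nM. Compound 3 `COc1ncnc2c1c(I)cn2[C@@H]1O[C@H](CO)[C@@H](O)[C@H]1O` keeps the methoxy group but carries iodo in place of thiophen-2-yl. In this assay compound 3 also gives only a limit, > 20000 nM. Compound 3 therefore stands at the weak end of the numbers shown, at the limit of > 20000 nM in this assay, at which 2 of the 3 values shown sit. For the measured compounds named here, the one measured step, an at least 45-fold higher number from compound 2 to compound 3 (1.65 log units; beyond the scatter), shows that exchanging thiophen-2-yl for iodo costs a great deal of potency.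

Compound 4 `COc1ncnc2c1c(-c1cc3ccccc3o1)cn2[C@@H]1O[C@H](CO)[C@@H](O)[C@H]1O` has not yet been measured. It differs from compound 3 by 1-benzofuran-2-yl in place of iodo on an aromatic carbon. The measured step ran the other way, from a ring to iodo, so restoring a ring in place of iodo is expected to lower the number substantially. Compound 1 tempers this: it carries the same 1-benzofuran-2-yl group with a methyl group and sits at the limit. Compound 4 is thus expected to be more potent than compound 3, by an estimated at least 10-fold lower number from compound 3 to compound 4 (1.00 log units; beyond the scatter). Compound 4 is estimated at 2000 nM, between 300 nM and 20000 nM.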

Compound 4, half-maximal inhibitory concentration: 14500 nM
Compound 4: middle estimate off by 7.3-fold (0.86 log units), on the low side, within the range that was stated.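

At this place on the five-membered aromatic ring, putting an aromatic ring in place of iodo does not by itself restore potency: in this assay, 1-benzofuran-2-yl gives an at least 1.3-fold lower number from compound 3 to compound 4 (0.13 log units; that floor lies within the scatter). Which ring enters therefore matters greatly, as 1-benzofuran-2-yl in place of thiophen-2-yl gives a 33-fold higher number from compound 2 to compound 4 (1.52 log units; beyond the scatter), the first sign that two aromatic rings on the same carbon can behave very differently. Methoxy in place of methyl gives an at least 1.3-fold lower number from compound 1 to compound 4 (0.13 log units; that floor lies within the scatter), and this step, like the one from iodo, is only a floor, set by a limit rather than by a number: the limit of > 20000 nM in this assay, at which 2 of the 4 values shown sit.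

The compounds shown leave open whether the loss from thiophen-2-yl to 1-benzofuran-2-yl goes with the added six-membered ring or with oxygen in place of sulfur, and a furan-2-yl or 1-benzothiophen-2-yl group on this carbon would separate the two. Also open, as far as these compounds go, is how thiophen-2-yl behaves when the methoxy group is replaced by methyl or by an amine.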